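The compounds below may be only part of what the source reports. "The series", "measured", "known", "first", "only" and "open" are said of these compounds alone.

Measured so far in a functional assay on MGC-803 cells (Homo sapiens) for inhibition, read by MTT assay, with a stated time of 72 h; on this read-out lower numbers stand for stronger inhibition and higher numbers for weaker inhibition:
compound 1 `Cc1cc(N2CC[C@@H](C)[C@@H](N(C)c3ncnc4[nH]ccc34)C2)n2nc(SCC3CCCCC3)nc2n1`: 9170 nM
compound 2 `Cc1cc(N2CC[C@@H](C)[C@@H](N(C)c3ncnc4[nH]ccc34)C2)n2nc(SCc3nc4ccccc4[nH]3)nc2n1`: 21200 nM
compound 3 `Cc1cc(N2CC[C@@H](C)[C@@H](N(C)c3ncnc4[nH]ccc34)C2)n2nc(SCCCc3ccccc3)nc2n1`: > 100000 nM

Compound 1 has the lowest of the two numbers given in this assay, with compound 2 nearest. For compound 3 the value in this assay is a limit of the assay, not a number. Compound 4 `Cc1cc(N2CC[C@@H](C)[C@@H](N(C)c3ncnc4[nH]ccc34)C2)n2nc(SCc3ccc(F)cc3)nc2n1` differs from compound 1 by 4-fluorophenyl in place of cyclohexyl on a saturated chain carbon bound to a sulfur. Among the compounds with values here, two measured steps bear on this: a 2.3-fold higher number from compound 1 to compound 2 (0.36 log units; beyond the scatter) and an at least 10-fold higher number from compound 1 to compound 3 (1.03 log units; beyond the scatter). Each replacement of cyclohexyl raised the number, and the aromatic 1H-benzimidazol-2-yl, like the entering 4-fluorophenyl, did so in a 2.3-fold higher number from compound 1 to compound 2 (0.36 log units; beyond the scatter). A step of similar direction is therefore expected, a 2.0-fold higher number from compound 1 to compound 4 (0.29 log units; within the scatter). Compound 4 is expected to give 18000 nM in this assay, somewhere between 7000 nM and 50000 nM.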

Compound 4, half-maximal inhibitory concentration: 11900 nM
Compound 4: middle estimate off by 1.5-fold (0.18 log units), on the high side, and the stated range covers the measured number.
By their numbers in this assay, from the lowest: compounds 1, 4 and 2 (each within the scatter of the next, the first and the last beyond it). At a limit, above all of these: compound 3.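

In this assay, 4-fluorophenyl on a saturated chain carbon bound to a sulfur does about as well as cyclohexyl, a 1.3-fold higher number from compound 1 to compound 4 (0.11 log units; within the scatter), so an aromatic ring at this place need not raise the number. It also stays close to 1H-benzimidazol-2-yl, a 1.8-fold lower number from compound 2 to compound 4 (0.25 log units; within the scatter), while phenethyl stands well apart, an at least 8.4-fold lower number from compound 3 to compound 4 (0.92 log units; beyond the scatter). Compound 3 has a limit of the assay rather than a number: the limit of > 100000 nM in this assay, at which 1 of the 4 values shown sits.

Open, from the compounds shown here alone, is whether the fluorine matters, as plain phenyl would show. Also open is whether an amine or a carboxylic acid on this ring would give a lower number than any shown here.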